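The source may hold more compounds than are shown below. What is called first, only, known or untested is meant among the compounds shown, and "the series" means these compounds.

Measured in a functional assay on the whole organism (stomach) for inhibition, with Rattus norvegicus as the target; a lower number here means that less compound is needed, a higher number that more compound is needed for the effect:
Compound 1 `COc1ccc(C[S+]([O-])c2ncccc2C(=O)Nc2ccncc2)c(OC)c1`: 4.2 mg/kg
Compound 2 `CCOc1ccc(C[S+]([O-])c2ncccc2C(=O)Nc2ccncc2)c(OCC)c1`: 11.2 mg/kg
Compound 3 `COc1cc(OC)c(C[S+]([O-])c2ncccc2C(=O)Nc2ccncc2)c(OC)c1`: 6.8 mg/kg

Among these three numbers, compound 3 at 6.8 mg/kg lies between the other two and within the scatter of each. The next structure is compound 4 `COc1cc(C)c(C[S+]([O-])c2ncccc2C(=O)Nc2ccncc2)c(OC)c1`, which has methyl in place of methoxy on an aromatic carbon, ortho to a large group and meta to two methoxy groups: methyl in place of methoxy on an aromatic carbon. Among the measured compounds shown here, one measured step bears on this change. It is the methoxy in place of hydrogen on that same aromatic carbon, a 1.6-fold higher number from compound 1 to compound 3 (0.21 log units; within the scatter). Putting a methoxy at this carbon therefore moved the number by no more than the scatter, and the series holds no direct measurement of a methyl there. No step beyond the scatter is thus expected in this assay, and no direction can be favoured with confidence. The estimated step is a 1.1-fold lower number from compound 3 to compound 4 (0.05 log units; within the scatter). For compound 4 the expected value is 6 mg/kg, with an estimated range from 3 mg/kg to 12 mg/kg.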

Compound 4, dose for half-maximal effect: 5.7 mg/kg
For compound 4 the middle estimate is 1.1-fold (0.02 log units) above the measured one, within the range that was stated.
By their numbers in this assay, from the lowest: compounds 1, 4, 3 and 2 (each within the scatter of the next, the first and the last beyond it).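

In this assay, the exchange of methoxy for methyl on this aromatic carbon gives a 1.2-fold lower number from compound 3 to compound 4 (0.08 log units; within the scatter), and methyl in place of hydrogen gives a 1.4-fold higher number from compound 1 to compound 4 (0.13 log units; within the scatter). Among the compounds shown here, this carbon, ortho to a large group and meta to two methoxy groups, has now carried hydrogen, methoxy and methyl, and all steps among the three stay within the scatter, whereas the earlier compounds showed this only for methoxy against hydrogen. No measurement at hand offers an explanation for this result.

On these data alone, whether an amine, a carboxylic acid or a longer chain on this carbon would also leave the number within the scatter remains open. As far as these compounds go, compounds 1, 3 and 4 all keep the two methoxy groups, so it is also open whether the same holds when those are replaced.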